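A few compounds are considered here, and "the series" means these few. Any claim that something is new, unique, unknown or untested is made for them only; others in the source may bear on it.

Measured compounds in a toxicity assay on MDCK cells (Canis lupus familiaris) for cytotoxicity, read by crystal violet staining, with a stated time of 48 h; a higher number here means that more compound is tolerated, a lower number that less compound is tolerated:
Compound 1 `CCc1ccc2[nH]c(=O)c(CN(Cc3ccc(C(C)(C)C)cc3)C(C)c3ccc(F)cc3)cc2c1` gives 2800 nM.
Compound 2 `CCc1ccc2[nH]c(=O)c(CN(Cc3ccc(C(C)(C)C)cc3)[C@@H](C)c3ccc(F)cc3)cc2c1` gives > 5000 nM, which is a limit of the assay and not a number.
Compound 3 `CCc1ccc2[nH]c(=O)c(CN(Cc3ccc(C(C)(C)C)cc3)[C@@H](C)c3ccc(OC)cc3)cc2c1` gives > 5000 nM, again a limit of the assay and not a number.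

Compound 3 thus stands at the limit, as does compound 2, and only compound 1 has a numerical value. The step of an at least 1.7-fold higher number from compound 1 to compound 3 (0.25 log units; that floor lies within the scatter) and the step of an at least 1.7-fold higher number from compound 1 to compound 2 (0.25 log units; that floor lies within the scatter) both reach only that floor, and their reading is governed by the limit of > 5000 nM in this assay, at which 2 of the 3 values shown sit, for the latter pair also by the fact that one of compounds 1 and 2 is drawn with a defined configuration and the other without, at the place where they differ. The step that the two limits leave unreadable from compound 2 to compound 3 cannot be sized at all.

Compound 4 `CCc1ccc2[nH]c(=O)c(CN(Cc3ccc(C(C)(C)C)cc3)C(C)c3ccc(OC)c(Cl)c3)cc2c1` differs from compound 3 by 1-(3-chloro-4-methoxyphenyl)ethyl in place of 1-(4-methoxyphenyl)ethyl on an amine nitrogen. The measured steps that bear on this are an at least 1.7-fold higher number from compound 1 to compound 3 (0.25 log units; that floor lies within the scatter), with its floor inside the scatter, and the unreadable a step that the two limits leave unreadable from compound 2 to compound 3. Neither step gives a change beyond the scatter, so no step beyond the scatter is expected here either. Compound 4 is therefore expected to sit near the limit again, with a step that the limit leaves unreadable from compound 3 to compound 4 expected to remain within the scatter. The estimate for compound 4 in this assay is 6000 nM, within the range 2500 nM to 15000 nM.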

Compound 4, half-maximal cytotoxic concentration: > 10000 nM
Compound 4 was reported as a limit (the forecaster's own chance of this, stated with the estimate: 65%); at least 1.6-fold (0.22 log units) between middle value and limit.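

In this assay, within the data shown here, compound 4 gives > 10000 nM as a limit of the assay and not a number. 3-Chloro-4-methoxyphenyl in place of 4-fluorophenyl on a saturated chain carbon bound to an amine nitrogen gives an at least 3.5-fold higher number from compound 1 to compound 4 (0.55 log units; beyond the scatter) and is the only step that reads beyond the scatter, with that carbon drawn without a configuration at both ends of the step. This step is only a floor, and the steps from compound 2 and from compound 3 to compound 4 cannot be read, as the assay limit governs them: the limit of > 10000 nM in this assay, at which 1 of the 4 values shown sits.

Going by these compounds, how much of the step from compound 1 belongs to the chlorine and how much to the methoxy remains open. Also open, on these data alone, are the effect of a defined configuration in the chlorinated series and whether a nitrile or a carboxylic acid in place of the chlorine would read the same way in this assay and stay near the limit.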